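The source may hold more compounds than are shown below. What is called first, only, known or untested is meant among the compounds shown, and "the series" means these compounds.

Measured so far in a functional assay on MCF7 cells (Homo sapiens) for antiproliferative activity, read by MTT assay, with a stated time of 72 h; a higher number here means a weaker inhibitor, a lower number a stronger inhibitor:
compound 1 `COc1cc2ncnc(N3CCc4ccccc43)c2cc1NC(=O)/C=C/CN1CCCC1` gives 1510 nM
compound 2 `COc1cc2ncnc(N3CCc4ccccc43)c2cc1NC(=O)/C=C/CN1CCCCC1` gives 1680 nM
compound 3 `O=C(/C=C/CN1CCCC1)Nc1cc2c(N3CCCc4ccccc43)ncnc2cc1O[C@@H]1CCOC1` gives 4250 nM

Compound 1 and compound 2 share a core and differ only by piperidin-1-yl in place of pyrrolidin-1-yl on a saturated chain carbon bound to a double-bonded chain carbon; the measured step is a 1.1-fold higher number from compound 1 to compound 2 (0.05 log units; within the scatter). Compound 3 is built on a different core; the difference between the core of compound 1 and the core of compound 3 is not broken down here. In this assay compound 3 stands highest of the three numbers, and its gaps to compound 1 and to compound 2 are both beyond the scatter.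

Compound 4 `O=C(/C=C/CN1CCCCC1)Nc1cc2c(N3CCCc4ccccc43)ncnc2cc1O[C@@H]1CCOC1` is not yet measured. It differs from compound 3 by piperidin-1-yl in place of pyrrolidin-1-yl on a saturated chain carbon bound to a double-bonded chain carbon, the same change as that from compound 1 to compound 2, at the same place. The expected step is a 1.1-fold higher number from compound 3 to compound 4 (0.03 log units; within the scatter), resting on a 1.1-fold higher number from compound 1 to compound 2 (0.05 log units; within the scatter), which lay within the scatter. Compound 4 is therefore expected to give 4600 nM in this assay, estimated to fall between 2500 nM and 8500 nM.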

Compound 4, half-maximal inhibitory concentration: 4450 nM
Compound 4: middle estimate off by 1.0-fold (0.01 log units), on the high side; the measured number falls inside the stated range.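

In this assay, piperidin-1-yl in place of pyrrolidin-1-yl on a saturated chain carbon bound to a double-bonded chain carbon gives a 1.0-fold higher number from compound 3 to compound 4 (0.02 log units; within the scatter). Set beside the earlier step, the change reads the same on both cores: the same change on two cores in this assay, a 1.1-fold higher number (0.05 log units; within the scatter) from compound 1 to compound 2 and a 1.0-fold higher number (0.02 log units; within the scatter) from compound 3 to compound 4, 1.1-fold (0.03 log units) apart, within the scatter of two such steps

This shows that the swap between these two rings carries from one core to the other in this assay, but only as a step within the scatter on both; it does not show that the same would hold on further cores or for other changes at this place. Still open, as far as these compounds go, is how an open-chain amine such as dimethylamino, or a ring with a second hetero atom such as morpholin-4-yl, would read on the same chain. Also open, from the compounds shown here alone, is which part of the difference between the core of compound 1 and the core of compound 3 goes with the gap between their numbers.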